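Trifluoromethyl in place of chloro on compound 1

This account rests on a few compounds, and the source may have more. Where it says the series, first, only, none or still open, it means among the compounds named here.

In a functional assay on HepG2 cells (Homo sapiens) for cytotoxicity, with a stated time of 24 h (a higher number here means a weaker inhibitor, a lower number a stronger inhibitor), compound 1 `COc1cc(Cl)ccc1C(=S)Nc1ccc(Cl)cc1O` gives 5110 nM. Compound 2 `COc1cc(Cl)ccc1C(=S)Nc1cc(Cl)c(Cl)cc1O` gives 3160 nM, and compound 3 `COc1cc(Cl)ccc1C(=S)Nc1cc(Br)ccc1O` gives 6530 nM. Compound 1 sits among these numbers without being separated from either of the others, since both of its gaps lie within the scatter.

Compound 4 `COc1cc(Cl)ccc1C(=S)Nc1ccc(C(F)(F)F)cc1O` has not yet been measured. Its change from compound 1 is trifluoromethyl in place of chloro on an aromatic carbon, meta to a hydroxy group and para to a large group.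

Going by the values given here, only one measured step between compounds differing in one place is available: a 1.6-fold lower number from compound 1 to compound 2 (0.21 log units; within the scatter). That step puts chloro in place of hydrogen on an aromatic carbon, so it is a different change and bears on this one only indirectly. Among the compounds with values here, no measured step replaces chloro with trifluoromethyl. The small size of that one step gives no reason to expect a shift in either direction, so no step beyond the scatter is expected in this assay. The expected step is a 1.1-fold lower number from compound 1 to compound 4 (0.06 log units; within the scatter). For compound 4 the estimated value is 4500 nM, with an expected range of 2000 nM to 10000 nM.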

Compound 4, half-maximal inhibitory concentration: 3140 nM
Compound 4: the middle estimate sits 1.4-fold (0.16 log units) above what was measured; low and high end bracket the measured number.
By their numbers in this assay, from the lowest: compounds 4, 2, 1 and 3 (each within the scatter of the next, the first and the last beyond it).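

Replacing chloro with trifluoromethyl on this aromatic carbon, meta to a hydroxy group and para to a large group, gives a 1.6-fold lower number from compound 1 to compound 4 (0.21 log units; within the scatter) in this assay. Going by these compounds alone, the earlier single-place step added a chloro in place of hydrogen and left this chloro untouched, so this is the first reading of a change at this carbon: 4 heavy atoms replace 1 heavy atom here, and the number stays within the scatter of compound 1. No measurement on hand explains this outcome.

The compounds shown leave open whether an amine, a carboxylic acid or a longer chain on this carbon would shift the number beyond the scatter, and what hydrogen at this place would give. Within the data shown here, with a single replacement read at this carbon, no trend with group size can be drawn, and the series so far offers no change at this place that separates from compound 1 in this cell assay.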